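A few compounds are considered here, and "the series" means these few. Any claim that something is new, unique, unknown or untested is made for them only; others in the source may bear on it.

In an ADME assay on MT4 cells (Homo sapiens) for cytotoxicity, read by MTT assay, with a stated time of 5 days (a lower number here means that less compound is tolerated, a higher number that more compound is tolerated), compound 3 `COc1cc2nc([S+]([O-])CC(=O)Nc3cccc(F)c3)nc(Nc3c(Cl)cc(/C=C/C#N)cc3Cl)c2cc1OC` gives 9550 nM and stands level with compound 1 `COc1cc2nc([S+]([O-])CC(=O)Nc3ccc(Cl)cc3)nc(Nc3c(Cl)cc(/C=C/C#N)cc3Cl)c2cc1OC` at 14400 nM on the same scale. The measured gap between these two, a 1.5-fold lower number from compound 1 to compound 3 (0.18 log units; within the scatter), is small. Compound 2 `COc1cc2nc([S+]([O-])CC(=O)Nc3ccccc3F)nc(Nc3c(Cl)cc(/C=C/C#N)cc3Cl)c2cc1OC` reads > 208000 nM and this is a limit of the assay, not a number.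

Compound 4 `COc1cc2nc([S+]([O-])CC(=O)Nc3ccccc3C(F)(F)F)nc(Nc3c(Cl)cc(/C=C/C#N)cc3Cl)c2cc1OC` keeps the shared core and changes one place, on an amide-type nitrogen, where 2-(trifluoromethyl)phenyl stands in place of 3-fluorophenyl (2-(trifluoromethyl)phenyl in place of 3-fluorophenyl on an amide-type nitrogen). Within the data shown here, no measured step makes this exact swap. The nearest guides are the two steps that touch compound 2, whose 2-fluorophenyl carries the same leading number as the entering group. These are an at least 14-fold higher number from compound 1 to compound 2 (1.15 log units; beyond the scatter) and an at least 21-fold lower number from compound 2 to compound 3 (1.33 log units; beyond the scatter), and both are large. Still, this rests on a single compound, and a trifluoromethyl group is not a lone fluorine, so only part of that size is carried over here.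

A higher number is therefore expected in this assay, an estimated 4.2-fold higher number from compound 3 to compound 4 (0.62 log units; beyond the scatter), which is smaller than those two steps. For compound 4 the expected value is 40000 nM, with an estimated range from 9000 nM to 200000 nM.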

Compound 4, half-maximal cytotoxic concentration: > 192000 nM
Compound 4: no number, only a limit (the forecaster's own chance of this, stated with the estimate: 40%); at least 4.8-fold (0.68 log units) between middle value and limit.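

On the amide-type nitrogen, 2-(trifluoromethyl)phenyl gives a second compound that reaches the top of the readable range in this assay, with an at least 20-fold higher number from compound 3 to compound 4 (1.30 log units; beyond the scatter) and an at least 13-fold higher number from compound 1 to compound 4 (1.12 log units; beyond the scatter), so the large rise seen with the 2-fluorophenyl of compound 2 no longer rests on a single compound. Compound 4 therefore gives a limit and not a number: the limit of > 192000 nM in this assay, at which 1 of the 4 values shown sits. From the compounds shown here alone, compound 2 also gives only a limit, so the step from compound 2 to compound 4 cannot be read, and it remains unknown whether trifluoromethyl and fluoro differ at all in this assay.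

Among these four compounds, the two highest readings belong to the two groups named with a leading 2, and neither compound 1 nor compound 3 goes against this, but four compounds are a small basis and the true tolerated concentrations of compound 2 and compound 4 remain unknown. The compounds shown also leave open whether a methoxy group or an amine in place of the fluorine of compound 2 would give a similar result, which would help show how much depends on the particular group.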